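A few compounds are considered here, and "the series" means these few. Any claim that something is new, unique, unknown or untested is made for them only; others in the source may bear on it.

Three compounds share a common core in which a five-membered aromatic ring bearing two nitrogens is attached to a larger fused system that carries a further aromatic arm. Compound 1 `Cn1cc(-c2ccc3cnn(Cc4ccc5ncccc5c4)c3c2)cn1` and compound 2 `CC(C)(C)[Si](C)(C)O[C@H]1CC[C@H](n2cc(-c3ccc4cnn(Cc5ccc6ncccc6c5)c4c3)cn2)CC1` have one arrangement of that core, while compound 3 `Cn1cc(-c2ccc3cn(Cc4ccc5ncccc5c4)nc3c2)cn1` carries the same groups on a differently arranged core. In a functional assay on MKN-45 cells (Homo sapiens) for cytotoxicity, read by Western blot, with a stated time of 1 h (on this read-out lower numbers stand for stronger inhibition and higher numbers for weaker inhibition), compound 1 gives 12900 nM, compound 2 gives 11000 nM, and compound 3 gives 106000 nM. Compound 3 thus stands highest of the three, with compound 1 nearest and compound 2 furthest, and both gaps lie beyond the usual scatter.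

Compound 4 `O[C@H]1CC[C@H](n2cc(-c3ccc4cn(Cc5ccc6ncccc6c5)nc4c3)cn2)CC1` differs from compound 3 by 4-hydroxycyclohexyl in place of methyl on an aromatic nitrogen. Among the measured compounds shown here, no measured pair shows exactly this change. Compounds 1 and 2 differ at the same ring nitrogen by a related, protected version of such a group, and their values in this assay sit within the scatter of each other. The step from compound 3 to compound 4 is therefore expected to be small, a 1.5-fold lower number from compound 3 to compound 4 (0.18 log units; within the scatter), at most a slight drift toward lower numbers and not clearly beyond the scatter. Compound 4 is estimated at 70000 nM in this assay, within a range from 25000 nM to 200000 nM.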

Compound 4, half-maximal inhibitory concentration: 13400 nM
The estimate for compound 4 lay 5.2-fold (0.72 log units) above the measured number; measured number below the stated range.
By their numbers in this assay, from the lowest: compounds 2, 1 and 4 (each within the scatter of the next); then compound 3.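

Among the compounds shown here, with 4-hydroxycyclohexyl in place of methyl on an aromatic nitrogen, the result is a 7.9-fold lower number from compound 3 to compound 4 (0.90 log units; beyond the scatter) in this assay and gives the first measured step at this position. This nitrogen of the shared core therefore accepts a group carrying a non-aromatic carbon ring and a hydroxyl, and in this pair the number falls rather than rises. No separate measurement here explains the drop.

Going by these compounds, what remains open is whether the carbon ring, the hydroxyl or the two together account for the step, since they enter as one change. A plain cyclohexyl would test the ring alone, while an amine in place of the hydroxyl or a longer chain bearing a hydroxyl would show how much this position depends on that particular group.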